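Moving the Chlorine on the Benzylsulfanyl Arm

This account rests on a few compounds, and the source may have more. Where it says the series, first, only, none or still open, it means among the compounds named here.

Compound 1 `Cc1cc(S(=O)(=O)/N=C(\N)n2nccc2-c2ccccc2)c(SCc2ccccc2Cl)cc1Cl` gives 24000 nM in a functional assay on MCF7 cells (Homo sapiens) for cytotoxicity, read by MTT assay, with a stated time of 72 h (on this read-out higher numbers stand for weaker inhibition and lower numbers for stronger inhibition), the lowest of the two numbers shown; compound 2 `Cc1cc(-c2ccccc2)n(/C(N)=N/S(=O)(=O)c2cc(C)c(Cl)cc2SCc2ccccc2C)n1` gives 80000 nM in this assay, and the gap between the two lies beyond the scatter. Compound 3 `Cc1cc(S(=O)(=O)/N=C(\N)n2nccc2-c2ccccc2)c(SCc2cccc(Cl)c2)cc1Cl` has not yet been measured; it differs from compound 1 as 3-chlorophenyl in place of 2-chlorophenyl on a saturated chain carbon bound to a sulfur. Nothing measured here tells how such a change moves the numbers, so no step beyond the scatter is expected in either direction. Compound 3 is therefore expected to give about 25000 nM in this assay, between 10000 nM and 60000 nM. The estimated step of a 1.0-fold higher number from compound 1 to compound 3 (0.02 log units; within the scatter) is expected to remain within the scatter.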

Compound 3, half-maximal inhibitory concentration: 88000 nM
The estimate for compound 3 lay 3.5-fold (0.55 log units) below the measured number; the whole stated range lies below it.
By their numbers in this assay, from the lowest: compound 1; then compounds 2 and 3 (each within the scatter of the next).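

Moving the chlorine alone, with the same atoms joined differently, is enough to matter in this assay: 3-chlorophenyl in place of 2-chlorophenyl on a saturated chain carbon bound to a sulfur brings a 3.7-fold higher number from compound 1 to compound 3 (0.56 log units; beyond the scatter). The arm at this position therefore responds to where its chlorine sits, and of these two placements the 2-chlorophenyl gives the stronger inhibition. Nothing available accounts for the shift. Still open, from the compounds shown here alone, is how 4-chlorophenyl would compare, and whether a methoxy group in place of the chlorine, or a longer chain to the ring, would keep the number of compound 1 or move it further.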